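Butoxy to bromo: the step to compound 4

A few compounds are considered here, and "the series" means these few. Any claim that something is new, unique, unknown or untested is made for them only; others in the source may bear on it.

Measured in a functional assay on HepG2 cells (Homo sapiens) for antiproliferative activity, read by MTT assay, with a stated time of 48 h; a lower number here means a stronger inhibitor, a higher number a weaker inhibitor:
- compound 1 `CCCCCCCCCCCCOc1ccc(C(=O)/C=C/c2c(/C=C/c3ccc(OC)cc3)cc(OC)cc2OC)cc1`: 11.6 ug/mL
- compound 2 `COc1ccc(/C=C/c2cc(OC)cc(OC)c2/C=C/C(=O)c2ccc(C)cc2)cc1`: 4.8 ug/mL
- compound 3 `CCCCOc1ccc(C(=O)/C=C/c2c(/C=C/c3ccc(OC)cc3)cc(OC)cc2OC)cc1`: 12.9 ug/mL

Compound 3 stands at the upper end of these numbers. Shortening the chain gives a 1.1-fold higher number from compound 1 to compound 3 (0.05 log units; within the scatter), while butoxy in place of methyl gives a 2.7-fold higher number from compound 2 to compound 3 (0.43 log units; beyond the scatter).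

Compound 4 `COc1ccc(/C=C/c2cc(OC)cc(OC)c2/C=C/C(=O)c2ccc(Br)cc2)cc1` carries bromo in place of butoxy on an aromatic carbon. Among the compounds with values here, no bromo compound has been measured yet. The nearest guide is compound 2 at 4.8 ug/mL, which also lacks the alkoxy chain. A modest move in this assay towards a lower number is therefore expected, though probably not the whole of that gap. The expected step is a 1.8-fold lower number from compound 3 to compound 4 (0.27 log units; within the scatter). Compound 4 is estimated at 7 ug/mL, with an expected range of 3.5 ug/mL to 14 ug/mL.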

Compound 4, half-maximal inhibitory concentration: 12.9 ug/mL
Estimate against measurement, compound 4: 1.8-fold (0.27 log units) below; the measured number falls inside the stated range.
By their numbers in this assay, from the lowest: compound 2; then compounds 1, 3 and 4 (each within the scatter of the next).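

In this assay bromo in place of butoxy gives no change at the digits printed from compound 3 to compound 4 (within the scatter) and so losing the alkoxy chain does not by itself lead to the lower number of compound 2. Bromo in place of methyl gives a 2.7-fold higher number from compound 2 to compound 4 (0.43 log units; beyond the scatter) so, among the groups shown on this aromatic carbon, only methyl stands apart. Nothing available explains why methyl differs from bromo here.

From the compounds shown here alone, whether plain hydrogen, chloro or an amine on this carbon would fall with methyl or with bromo remains open.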